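A few compounds are considered here, and "the series" means these few. Any claim that something is new, unique, unknown or untested is made for them only; others in the source may bear on it.

The measured compounds:

compound 1, `COc1ccc(CNC(=O)/C(C#N)=C/c2ccc3ccccc3c2)cc1`, giving 43000 nM
compound 2, `COc1ccc(CNC(=O)/C(C#N)=C/c2cccc3ccccc23)cc1`, giving 15000 nM
compound 3, `N#C/C(=C\c1ccc2ccccc2c1)C(=O)NCc1ccc(Cl)c(Cl)c1`, giving 64000 nM

All three were tested in a functional assay on SMA cells (Homo sapiens) for inhibition, read by MTT assay, with a stated time of 72 h; a lower number here means a stronger inhibitor of growth, a higher number a weaker inhibitor of growth. Compound 2 has the lowest number of the three; the gap from compound 1 to compound 2 and the gap from compound 3 to compound 2 both lie beyond the usual scatter of this assay. Compound 1 and compound 2 are built from the same atoms joined differently; how their two cores differ is not broken down here.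

Compound 3 is compound 1 with one change: 3,4-dichlorophenyl in place of 4-methoxyphenyl on a saturated chain carbon bound to an amide-type nitrogen. That change made a step of a 1.5-fold higher number from compound 1 to compound 3 (0.17 log units; within the scatter), which is within the scatter, so the two compounds cannot be ranked against each other.

Compound 4, `N#C/C(=C\c1cccc2ccccc12)C(=O)NCc1ccc(Cl)c(Cl)c1`, has not yet been measured. It stands to compound 2 as compound 3 stands to compound 1: 3,4-dichlorophenyl in place of 4-methoxyphenyl on a saturated chain carbon bound to an amide-type nitrogen. The same change therefore occurs in two pairs of compounds, and the place it sits in is described in the same words for both pairs.

Among the measured compounds shown here, with only one earlier example of this change, the expectation rests on a single step. Compound 4 is expected to sit close to compound 2, with an estimated step of a 1.3-fold higher number from compound 2 to compound 4 (0.12 log units; within the scatter), because the same change gave a 1.5-fold higher number from compound 1 to compound 3 (0.17 log units; within the scatter), a step within the scatter. Compound 4 is therefore estimated at 20000 nM, with a likely range from 8000 nM to 55000 nM.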

Compound 4, concentration for 50% growth inhibition: 7000 nM
The estimate for compound 4 lay 2.9-fold (0.46 log units) above the measured number; the measured number lies below the stated range.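

In this assay, swapping the two substituted phenyl groups gave a 2.1-fold lower number from compound 2 to compound 4 (0.33 log units; beyond the scatter), so on the core of compound 2 the change made a stronger inhibitor of growth, though only by a modest step. The same change therefore cannot simply be carried from the core of compound 1 to the core of compound 2 with the same result, since the two steps clearly differ: the same change on two cores in this assay, a 1.5-fold higher number (0.17 log units; within the scatter) from compound 1 to compound 3 and a 2.1-fold lower number (0.33 log units; beyond the scatter) from compound 2 to compound 4, 3.2-fold (0.50 log units) apart, beyond the scatter of two such steps. This shows that, in this assay, the result of the change depends on the core it is made on, but it rests on just two pairs of compounds, so it does not explain the difference or predict the size or direction of the step on any further core.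

The compounds shown leave open how a plain phenyl or a 4-chlorophenyl group would behave in the same place on each core, and whether an amine or a carboxylic acid on that ring would follow either step. They also leave open whether a longer chain carrying the ring would keep the difference between the two cores.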